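Removing one methyl from the gem-dimethyl carbon of compound 2

The source may hold more compounds than are shown below. What is called first, only, known or untested is meant among the compounds shown, and "the series" means these compounds.

In an assay on cells for inhibition of cytochrome P450 11B2, mitochondrial (Homo sapiens), read by HTRF (on this read-out lower numbers stand for stronger inhibition and higher numbers for weaker inhibition), compound 2 `CC1(C)c2cc(Cl)ccc2C(=O)N1c1cccnc1` gives 108 nM. Compound 1 `O=C1c2ccc(Cl)cc2CN1c1cccnc1` gives 179 nM in this assay; its number and that of compound 2 lie within the scatter of each other, so nothing separates them. Compound 3 `CC1c2cc(Cl)ccc2C(=O)N1c1cccnc1` differs from compound 2 by hydrogen in place of methyl on a saturated ring carbon. For the measured compounds named here, no measured pair mirrors this change, so no step beyond the scatter is expected in this assay in either direction. Compound 3 is expected at 150 nM, within 60 nM to 400 nM, an estimated step of a 1.4-fold higher number from compound 2 to compound 3 (0.14 log units; within the scatter).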

Compound 3, half-maximal inhibitory concentration: 123 nM
Estimate against measurement, compound 3: 1.2-fold (0.09 log units) above; low and high end bracket the measured number.
By their numbers in this assay, from the lowest: compounds 2, 3 and 1 (each within the scatter of the next).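

Hydrogen in place of methyl on this saturated ring carbon brings no separable change in this assay (a 1.1-fold higher number from compound 2 to compound 3 (0.06 log units; within the scatter)), and methyl in place of hydrogen brings none either (a 1.5-fold lower number from compound 1 to compound 3 (0.16 log units; within the scatter)). With no, one or two methyls on this carbon, the read-out does not tell compounds 1, 2 and 3 apart. Nothing at hand bears on the reason for this.

Open, on these data alone, is how this carbon responds to a group other than methyl, such as an ethyl chain, a hydroxymethyl or an amine. The compounds shown also say nothing about substituents elsewhere on the shared core.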